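Pyrimidinyl amine in place of imidazolyl sulfonamide: cytotoxicity expectation

The source may hold more compounds than are shown below. What is called first, only, known or untested is meant among the compounds shown, and "the series" means these compounds.

Compound 1 `CC(Cn1ccc(-c2ccc(C#N)c(Cl)c2)n1)C(=O)Nc1cccc(C(C)O)c1`, compound 2 `CC(=O)c1ccc(S(=O)(=O)N[C@@H](C)Cn2ccc(-c3ccc(C#N)c(Cl)c3)n2)cc1` and compound 3 `C[C@@H](Cn1ccc(-c2ccc(C#N)c(Cl)c2)n1)NS(=O)(=O)c1cn(C)cn1` share a core and were examined in an ADME assay on PC-3 cells (Homo sapiens) for cytotoxicity, read by CCK-8 assay, with a stated time of 6 days; on this read-out higher numbers stand for weaker inhibition and lower numbers for stronger inhibition. In this assay compound 1 gives > 30000 nM, a limit of the assay and not a number. Compound 2 gives > 30000 nM, again a limit. Compound 3 gives > 30000 nM, likewise a limit. For the measured compounds named here, the only single-point step among them, a step that the two limits leave unreadable from compound 2 to compound 3, is therefore unreadable, because both of its ends rest on (the limit of > 30000 nM in this assay, at which 3 of the 3 values shown sit). Compound 4 `C[C@@H](Cn1ccc(-c2ccc(C#N)c(Cl)c2)n1)Nc1cncnc1` is the next compound; it differs from compound 3 by pyrimidin-5-yl in place of (1-methyl-1H-imidazol-4-yl)sulfonyl on an amine nitrogen. Going by the values given here, no measured step bears on this change in a readable way, so the account leans on the observation that every value so far sits at the limit. Compound 4 is therefore expected to show no step beyond the scatter, a step that the limit leaves unreadable from compound 3 to compound 4, and most likely to return another limit. The estimated value of compound 4 in this assay is 50000 nM, with a range from 20000 nM to 200000 nM.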

Compound 4, half-maximal inhibitory concentration: > 30000 nM
Compound 4 gave a limit, no number; the forecaster's own chance of this, stated with the estimate: 85%; the middle value is on the limit's open side.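

In this assay compound 4 gives > 30000 nM, a limit of the assay and not a number. No step from compound 3 to compound 4 can be read, because both ends rest on a limit: the limit of > 30000 nM in this assay, at which 4 of the 4 values shown sit.

The compounds shown leave open whether any change on the amine nitrogen alters cytotoxicity at all.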